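The compounds below may be only part of what the source reports. "The series", "measured", "known", "first", "only" and "open" are said of these compounds alone.

Compound 1 `Nc1ncc(-c2ccc(C(=O)N3CCC(O)C3)cc2)nc1-c1ccc(C(F)(F)F)cc1`: 77000 nM
Compound 2 `Nc1ncc(-c2ccc(C(=O)N3CC[C@@H](O)C3)cc2)nc1-c1ccc(C(F)(F)F)cc1`: 90000 nM
Compound 3 `N#Cc1ccc(-c2cnc(N)c(-c3ccc(N)nc3)n2)cc1`: < 5000 nM (a limit, not a number)

These three results come from a physicochemical assay for solubility, read by HPLC, using the shake flask method, in phosphate buffer, with a stated time of 2 h, at pH 6.5; a lower number here means a less soluble compound, a higher number a more soluble compound. Compound 2 stands level with compound 1, since the measured step is a 1.2-fold higher number from compound 1 to compound 2 (0.07 log units; within the scatter). All that separates these two is the fact that one of compounds 1 and 2 is drawn with a defined configuration and the other without, at the place where they differ. Compound 3 offers only a limit, so it gives no number to compare.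

The next structure is compound 4 `Nc1ncc(-c2ccc(C(=O)N3CCC(O)CC3)cc2)nc1-c1ccc(C(F)(F)F)cc1`, and the change from compound 2 is 4-hydroxypiperidin-1-yl in place of 3-hydroxypyrrolidin-1-yl on a carbonyl carbon. A six-membered non-aromatic ring thus takes the place of a five-membered one on the carbonyl carbon, with the hydrogen-bond donor and acceptor count unchanged. Among the measured compounds shown here, the only measured step, a 1.2-fold higher number from compound 1 to compound 2 (0.07 log units; within the scatter), leaves the ring size untouched, so it gives no direct guide to this change. With compound 2 at 90000 nM as the starting point, no step beyond the scatter is expected in this assay.

The expected step is a 1.4-fold lower number from compound 2 to compound 4 (0.14 log units; within the scatter).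

For compound 4 the estimated value is 65000 nM, with an expected range of 25000 nM to 130000 nM.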

Compound 4, solubility: 19000 nM
For compound 4 the middle estimate is 3.4-fold (0.53 log units) above the measured one; measured number outside the range, below it.
By their numbers in this assay, from the lowest: compound 4; then compounds 1 and 2 (each within the scatter of the next). At a limit, below all of these: compound 3.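

In this assay, the earlier pair differed only in how one stereocentre is drawn, and that step lay within the scatter, so the group on the carbonyl carbon had not yet been truly changed. With 4-hydroxypiperidin-1-yl in place of 3-hydroxypyrrolidin-1-yl, the measured step is a 4.7-fold lower number from compound 2 to compound 4 (0.68 log units; beyond the scatter) and the matching step is a 4.1-fold lower number from compound 1 to compound 4 (0.61 log units; beyond the scatter) so this position responds to the change, and both steps lie beyond the scatter although the counted hydrogen-bond donors and acceptors stay the same. Nothing measured for these compounds accounts for the size of this step.

The ring size and the place of the hydroxyl change together here, so the two cannot be told apart. Going by these compounds, a 3-hydroxypiperidin-1-yl group would keep the hydroxyl numbering of the five-membered ring on a six-membered ring, and a morpholine or a 4-aminopiperidin-1-yl group remains open too.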